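The source may report more compounds than this note shows. Statements on the series, on what has been measured and on what is new or still open speak of the compounds shown alone.

In a functional assay on MGC-803 cells (Homo sapiens) for antiproliferative activity, read by CCK-8 assay, with a stated time of 72 h, tested at 8 uM (on this read-out higher numbers stand for a stronger effect at the one concentration tested and lower numbers for a weaker effect), compound 2 `Nc1ccccc1NC(=O)c1ccc(CSC(=S)N2CCN(c3ncccn3)CC2)cc1` gives 64.8%, and compound 1 `Nc1ccccc1NC(=O)c1ccc(CSC(=S)N2CCN(Cc3ccccn3)CC2)cc1` gives 65.2%; the two stand within the scatter of each other, the step being a number 0.4 percentage points lower from compound 1 to compound 2 (within the scatter). Compound 3 `Nc1ccccc1NC(=O)c1ccc(CSC(=S)N2CCN(c3cnccn3)CC2)cc1` differs from compound 2 by pyrazin-2-yl in place of pyrimidin-2-yl on an amine nitrogen in a ring. For the measured compounds named here, the only measured step, an exchange of one aromatic group for another on the same ring nitrogen, stayed within the scatter, so a step of a number 1.8 percentage points lower from compound 2 to compound 3 (within the scatter) is expected here, none beyond the scatter. Compound 3 is therefore estimated to give 63% in this assay, with a range from 50% to 76%.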

Compound 3, a percentage reported as inhibition, at one concentration (the size of the read-out at that concentration, not a potency): 80.5%
Beside the measured number, compound 3's estimate is 17.5 percentage points below it; the whole stated range lies below it.
By their numbers in this assay, from the lowest: compounds 2 and 1 (each within the scatter of the next); then compound 3.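

The group on this ring nitrogen can matter in this assay: swapping pyrazin-2-yl for pyrimidin-2-yl, two groups with the same atoms joined differently, gives a number 15.7 percentage points higher from compound 2 to compound 3 (beyond the scatter), so the arrangement of atoms within the aromatic group counts, even though the earlier exchange stayed within the scatter. Pyrazin-2-yl in place of (pyridin-2-yl)methyl likewise gives a number 15.3 percentage points higher from compound 1 to compound 3 (beyond the scatter). Nothing available explains this gain. Still open, as far as these compounds go, is how a phenyl group, or a pyridin-2-yl group, on the same nitrogen would compare with pyrazin-2-yl.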